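The source may hold more compounds than are shown below. What is called first, only, known or untested is meant among the compounds shown, and "the series" means these compounds.

Compound 3, `CC(=O)N[C@@H]1CCC[C@H](C(=O)Nc2cc(-c3cnn4c3CC(C)(C)C4)c(Cl)cn2)C1`, is one of three close relatives that share a core and differ only in the group carried on one aromatic carbon of that core. In an ADME assay on cells (Hepatocyte, Homo sapiens) for metabolic stability, using equilibrium dialysis (a lower number here means slower removal, a higher number faster removal of the compound), compound 3 gives 3.5 uL/min, the lower of the two numbers recorded, and the gap to compound 2, `CC(=O)N[C@@H]1CCC[C@H](C(=O)Nc2cc(-c3cnn4c3CCCCC4)c(Cl)cn2)C1`, which gives 4.6 uL/min, is a 1.3-fold lower number from compound 2 to compound 3 (0.12 log units; within the scatter). Compound 1, `CC(=O)N[C@@H]1CCC[C@H](C(=O)Nc2cc(-c3cnn(C)c3C)c(Cl)cn2)C1`, gives only a limit in this assay, < 1 uL/min, as recorded in the limit of < 1 uL/min in this assay, at which 1 of the 3 values shown sits. From that limit, the moves to the two larger groups were an at least 4.6-fold higher number from compound 1 to compound 2 (0.66 log units; beyond the scatter) and an at least 3.5-fold higher number from compound 1 to compound 3 (0.54 log units; beyond the scatter).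

Compound 4, `CC(=O)N[C@@H]1CCC[C@H](C(=O)Nc2cc(-c3cnc4n3CC(C)(C)C4)c(Cl)cn2)C1`, differs from compound 3 by a group of 10 heavy atoms (8 carbon, 2 nitrogen; one five-membered non-aromatic ring with 1 hetero atom, one five-membered aromatic ring with 2 hetero atoms) in place of a group of 10 heavy atoms (8 carbon, 2 nitrogen; one five-membered non-aromatic ring with 1 hetero atom, one five-membered aromatic ring with 2 hetero atoms), on an aromatic carbon; the two hold the same atoms, joined differently. Within the data shown here, no measured step repeats such a rearrangement. The nearest guide is the exchange between the groups of compound 2 and compound 3, a 1.3-fold lower number from compound 2 to compound 3 (0.12 log units; within the scatter), which stayed within the scatter, whereas the two steps beyond the scatter both began from the smaller group of compound 1. On that basis no step beyond the scatter is expected in this assay, and the step from compound 3 to compound 4 is estimated at no change at the digits printed from compound 3 to compound 4 (within the scatter). Compound 4 is accordingly expected to give 3.5 uL/min, with a likely range from 1.5 uL/min to 8 uL/min.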

Compound 4, intrinsic clearance in a liver preparation (reported as CLH), per the amount of preparation that the assay uses: 2.5 uL/min
Beside the measured number, compound 4's estimate is 1.4-fold (0.15 log units) above it, within the range that was stated.
By their numbers in this assay, from the lowest: compounds 4, 3 and 2 (each within the scatter of the next). At a limit, below all of these: compound 1.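

In this assay, joining the same atoms differently in the group on this aromatic carbon, opposite the ring nitrogen, gives a 1.4-fold lower number from compound 3 to compound 4 (0.15 log units; within the scatter), and setting this group against the seven-membered ring of compound 2 gives a 1.8-fold lower number from compound 2 to compound 4 (0.26 log units; within the scatter), so this read-out does not separate these three larger groups. The rearrangement therefore leaves the new group on the same side of the smaller group of compound 1 as the other two larger groups, with an at least 2.5-fold higher number from compound 1 to compound 4 (0.39 log units; beyond the scatter). Compound 1 is recorded only as a limit of the assay, so the full size of that step cannot be read: the limit of < 1 uL/min in this assay, at which 1 of the 4 values shown sits.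

The compounds shown leave open which part of the larger groups goes with the gap to compound 1, since the fused non-aromatic ring and the added carbon atoms enter together in every step from it. They also leave open whether a fluorine atom or a hydroxyl group on the five-membered non-aromatic ring would move the number in this assay beyond the scatter of these three compounds.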